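The source may report more compounds than this note shows. Statements on the series, on what has been measured and on what is new or still open speak of the compounds shown alone.

Compound 1 `COc1ccc(-c2nc3cc([N+](=O)[O-])ccc3[nH]2)c(OC)c1` carries a nitro group on its shared core. In an ADME assay on BHK cells (Mesocricetus auratus) for cytotoxicity, read by MTT assay, with a stated time of 96 h (a higher number here means that more compound is tolerated, a lower number that less compound is tolerated), compound 1 gives only > 100000 nM, which is a limit of the assay rather than a measured number. A second compound, compound 2 `CC(=O)Nc1ccc(-c2nc3cc(Cl)c(Cl)cc3[nH]2)cc1`, has been measured in the same way. In this assay compound 2 likewise reaches only > 100000 nM, again a limit of the assay. Compound 1 thus stands at the limit of > 100000 nM in this assay, at which 2 of the 2 values shown sit, so no numbered value sets it apart from the other measured compound. The compound not yet measured is compound 3 `COc1ccc(-c2nc3cc(C(F)(F)F)ccc3[nH]2)c(OC)c1`. It differs from compound 1 in one place: trifluoromethyl in place of nitro on an aromatic carbon. Among the compounds with values here, no measured pair of compounds shows what this kind of change does in this assay, and both measured values are limits. The step of a number no higher from compound 1 to compound 3 (the limit leaves the size open) is therefore expected to be none beyond the usual scatter. Compound 3 is expected to sit at the same limit as well. In this assay compound 3 is estimated at 100000 nM, within a range from 40000 nM to 300000 nM.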

Compound 3, half-maximal cytotoxic concentration: > 100000 nM
Compound 3: no number, only a limit; the forecaster's own chance of this, stated with the estimate: 75%; the middle value sits exactly at the limit.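

In this assay compound 3 gives > 100000 nM, which is a limit of the assay and not a number, so no step can be read between compound 1 and compound 3. All the compounds shown end up in the same place: the limit of > 100000 nM in this assay, at which 3 of the 3 values shown sit.

The compounds shown leave open at what concentration any of them harms the cells, and whether trifluoromethyl in place of nitro changes that concentration.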